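From 1H-indol-3-yl to 3,4-dimethylphenyl on the shared core

The source may hold more compounds than are shown below. What is called first, only, known or untested is meant among the compounds shown, and "the series" means these compounds.

In a functional assay on A549 cells (Homo sapiens) for inhibition, read by CCK-8 assay, with a stated time of 48 h (on this read-out lower numbers stand for stronger inhibition and higher numbers for weaker inhibition), compound 1 `COc1cc(-c2ccnc3cc(-c4cn(CO)c5ccccc45)nn23)cc(OC)c1OC` gives 167 nM, while compound 2 `COc1cc(-c2ccnc3cc(-c4c[nH]c5ccccc45)nn23)cc(OC)c1OC` gives 29 nM, the lower of the two numbers. Compound 3 `COc1cc(-c2ccnc3cc(-c4ccc(C)c(C)c4)nn23)cc(OC)c1OC` differs from compound 2 by 3,4-dimethylphenyl in place of 1H-indol-3-yl on an aromatic carbon, with 3,4-dimethylphenyl in place of 1H-indol-3-yl on an aromatic carbon. Among the measured compounds shown here, only one measured step bears on this: a 5.8-fold lower number from compound 1 to compound 2 (0.76 log units; beyond the scatter), a modest change beyond the scatter, made on an aromatic nitrogen of the group that now leaves. A step of similar size towards a higher number is expected, estimated as a 4.1-fold higher number from compound 2 to compound 3 (0.62 log units; beyond the scatter). Compound 3 is estimated at 120 nM, with an expected range of 25 nM to 700 nM.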

Compound 3, half-maximal inhibitory concentration: 272 nM
The estimate for compound 3 lay 2.3-fold (0.36 log units) below the measured number; the measured number falls inside the stated range.
By their numbers in this assay, from the lowest: compound 2; then compounds 1 and 3 (each within the scatter of the next).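

In this assay, replacing the whole 1H-indol-3-yl on this aromatic carbon with 3,4-dimethylphenyl gives a 9.4-fold higher number from compound 2 to compound 3 (0.97 log units; beyond the scatter), so the group at this position matters as well as the substituent on its nitrogen. The change removes the five-membered aromatic ring and the hydrogen-bond donor together, and these compounds cannot separate the two. Nothing available here accounts for the step. On these data alone, it remains open whether an amine on the phenyl ring in place of the two methyl groups would restore the number of compound 2. As far as these compounds go, whether a methyl group on the indole nitrogen would behave like hydroxymethyl also remains open.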